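The compounds below may be only part of what the source reports. "The series", "measured", "known", "first", "only" and "open" are said of these compounds alone.

For the measured compounds named here, in an ADME assay on a cell-free system (plasma, Rattus norvegicus, strain Sprague-Dawley) for metabolic stability, read by LC-MS, tested at 10 uM (a higher number here means that the compound lasts longer, a lower number that the compound disappears faster), compound 1 (`O=C(NO)C(Cc1ccccc1)C(=O)NCc1ccc(F)cc1`) gives 0.8 h and holds the lowest of the three numbers measured so far, beyond the scatter from both others. Compound 3 (`CC(Cc1ccccc1)(C(=O)NO)C(=O)NCc1ccc(F)cc1`) gives 3.6 h in this assay and compound 2 (`O=C(NO)/C(=C/c1ccccc1)C(=O)NCc1ccc(F)cc1`) gives 4.1 h in the same test.

The change under review leads to compound 4 (`O=C(CC(=O)NCc1ccc(F)cc1)NO`), with hydrogen in place of benzyl on a saturated chain carbon bound to two carbonyl carbons. Going by the values given here, one measured step bears on that carbon. Methyl in place of hydrogen there gave a 4.5-fold higher number from compound 1 to compound 3 (0.65 log units; beyond the scatter) and counts as a modest step beyond the scatter. Among the compounds with values here, that step adds to the carbon, whereas compound 4 loses a group from it, and no measured compound shows the loss of benzyl itself. On the evidence of that single step, a modest move to a shorter half-life is expected in this assay for compound 4, though a number close to that of compound 1 remains possible. The estimated step is a 2.3-fold lower number from compound 1 to compound 4 (0.36 log units; beyond the scatter) and it rests on one comparison only. For compound 4 the estimate is 0.35 h with an expected range of 0.12 h to 1.2 h on this reading.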

Compound 4, half-life: 10.5 h
For compound 4 the middle estimate is 30-fold (1.48 log units) below the measured one; the measured number lies above the stated range.
By their numbers in this assay, from the lowest: compound 1; then compounds 3 and 2 (each within the scatter of the next); then compound 4.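

At the saturated chain carbon bound to two carbonyl carbons, taking benzyl away moves the number in the same direction as adding methyl. In this assay, hydrogen in place of benzyl is a large step (a 13-fold higher number from compound 1 to compound 4 (1.12 log units; beyond the scatter)), and methyl in place of hydrogen is a modest one (a 4.5-fold higher number from compound 1 to compound 3 (0.65 log units; beyond the scatter)). Changes of opposite kind at this one carbon thus both leave compound 1 lower, so adding to the carbon is not the only route to a longer half-life, and benzyl is not required for one. No measurement given here accounts for either step.

Open, on these data alone, is how the number behaves between hydrogen and benzyl on this carbon, which a lone methyl or an ethyl in place of benzyl, or a longer chain such as phenylethyl, would help to place. Also open, as far as these compounds go, is whether the two changes add up, as a methyl on the same carbon of compound 4 or a second methyl there would test, and whether a pyridylmethyl in place of benzyl would behave as benzyl does.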